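Hydrogen for Methyl on the Benzyl Group

This account rests on a few compounds, and the source may have more. Where it says the series, first, only, none or still open, it means among the compounds named here.

In a functional assay on HCT-116 cells (Homo sapiens) for inhibition, read by sulforhodamine B assay, with a stated time of 3 days (a higher number here means a weaker inhibitor of growth, a lower number a stronger inhibitor of growth), compound 3 (`Cc1ccc(COc2ccc(C(=O)/C=C/c3ccc(Cl)cc3)cc2)cc1`) gives > 50000 nM, which is a limit of the assay and not a number. Compound 1 (`O=C(/C=C/c1ccccc1)c1ccc(OCc2ccccc2)cc1`) gives > 50000 nM, again a limit. Going by the values given here, compound 2 (`COc1cccc(/C=C/C(=O)c2ccc(OCc3ccccc3)cc2)c1`) gives 35400 nM, the only true number so far. The limit recurs across this small set: the limit of > 50000 nM in this assay, at which 2 of the 3 values shown sit.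

Compound 4 (`O=C(/C=C/c1ccc(Cl)cc1)c1ccc(OCc2ccccc2)cc1`) carries hydrogen in place of methyl on an aromatic carbon, so that 4-methylbenzyl becomes benzyl (hydrogen in place of methyl on an aromatic carbon). Among the compounds with values here, only one measured step is available, and it bears on this change only loosely. That step, an at least 1.4-fold lower number from compound 1 to compound 2 (0.14 log units; that floor lies within the scatter), is methoxy in place of hydrogen on an aromatic carbon, a different exchange, and it stays small. No step beyond the scatter is therefore expected in this assay, in either direction. The expected change is an at least 1.1-fold lower number from compound 3 to compound 4 (0.04 log units; that floor lies within the scatter), and it may well be hidden by the limit. For compound 4 the estimated value is 45000 nM, with an expected range from 25000 nM to 80000 nM.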

Compound 4, concentration for 50% growth inhibition: > 50000 nM
Compound 4 ended at the assay's limit; the forecaster's own chance of this, stated with the estimate: 65%; at least 1.1-fold (0.04 log units) between middle value and limit.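

With hydrogen in place of methyl on the benzyl group, the compounds carrying 4-chlorophenyl stay at the limit of the assay, and neither the step from compound 3 to compound 4 nor the step from compound 1 to compound 4 can be read, as both ends of each are limits. Going by these compounds alone, the one step that can be read, 4-chlorophenyl in place of 3-methoxyphenyl, is an at least 1.4-fold higher number from compound 2 to compound 4 (0.14 log units; that floor lies within the scatter), and so it shows no change beyond the scatter. The limit now holds most of the set: the limit of > 50000 nM in this assay, at which 3 of the 4 values shown sit.

Going by these compounds, whether an amine or a carboxylic acid in place of that methyl would give a true number in this assay stays open. So does how far compound 1, compound 3 and compound 4 actually lie past the limit, and with it whether the methyl matters at all.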